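Inverted ring stereocentres: from compound 2 to compound 4

A few compounds are considered here, and "the series" means these few. Any claim that something is new, unique, unknown or untested is made for them only; others in the source may bear on it.

Working notes on the series. Compound 1 `CC(=O)CC/C=C(\C)CCC1=C(C)CCCC1(C)C` and compound 3 `C=C1CCC[C@H]2[C@](C)(CC[C@]3(C)CC[C@@H]([C@@H](C)C(=O)O)OO3)[C@@H](C)CC[C@]12C` frame the set; in a functional assay on MDA-N cells (Homo sapiens) for inhibition (a higher number here means a weaker inhibitor of growth, a lower number a stronger inhibitor of growth), compound 3 gives 910 nM. For compound 1 the read-out is only a limit, > 15000 nM (the limit of > 15000 nM in this assay, at which 1 of the 3 values shown sits). Compound 2 `C=C1CCCC(C)(C)C1CC[C@]1(C)CC[C@@H]([C@@H](C)C(=O)O)OO1` likewise returns only a limit in this assay, > 10000 nM (the limit of > 10000 nM in this assay, at which 1 of the 3 values shown sits), so compound 2 has no number of its own and sits among the limit values shown. Compound 4 `C=C1CCCC(C)(C)C1CC[C@@]1(C)CC[C@H]([C@@H](C)C(=O)O)OO1` differs from compound 2 thus: the two compounds have the same atoms and bonds; at least one stereo element is drawn with a configuration in one of them and without one in the other: 2 of 4 stereo elements differ; a stereocentre at a saturated ring carbon is drawn R in compound 2 and S in compound 4; a stereocentre at a saturated ring carbon is drawn S in compound 2 and R in compound 4. For the measured compounds named here, no step between measured compounds is available, and no pair shows what inverting these stereocentres does; the expected step that the limit leaves unreadable from compound 2 to compound 4 is set at none beyond the scatter, with another limit the likeliest outcome. Compound 4 is estimated at 12000 nM, range 3000 nM to 40000 nM.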

Compound 4, concentration for 50% growth inhibition: 3520 nM
For compound 4 the middle estimate is 3.4-fold (0.53 log units) above the measured one; the range from low to high includes it.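

In this assay, for the compounds shown here, inverting the two saturated ring stereocentres gives an at least 2.8-fold lower number from compound 2 to compound 4 (0.45 log units; beyond the scatter), the first readable step, so the configuration at these ring carbons matters even with atoms and bonds unchanged. Compound 4 gives 3520 nM, a real number on this scaffold. Compound 2 remains a limit, so the size of the step has no upper end: the limit of > 10000 nM in this assay, at which 1 of the 4 values shown sits.

From the compounds shown here alone, both stereocentres change together, and which of them carries the step stays open. Also open, going by these compounds, is how a methyl ester in place of the carboxylic acid would read in the inverted series.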